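Compound 3 to compound 4: hydrogen for hydroxy

A few compounds are considered here, and "the series" means these few. Any claim that something is new, unique, unknown or untested is made for them only; others in the source may bear on it.

In a functional assay on CLL cells (Homo sapiens) for cytotoxicity, read by MTT assay, with a stated time of 48 h (on this read-out lower numbers stand for an effect already at smaller amounts and higher numbers for an effect only at larger amounts of compound), compound 1 (`C=C(CC)C(=O)c1ccc(OCC(=O)NCC(=O)O)c(Cl)c1Cl`) gives > 25000 nM, which is a limit of the assay. Compound 3 (`C=C(CC)C(=O)c1ccc(OCC(=O)Nc2ccc(C(=O)O)c(O)c2)c(Cl)c1Cl`) gives > 25000 nM, also a limit. For the measured compounds named here, compound 2 (`C=C(CC)C(=O)c1ccc(OCC(=O)Nc2ccc(C(=O)O)cn2)c(Cl)c1Cl`) gives 14900 nM as the only number so far. The series thus sits mostly at the limit of > 25000 nM in this assay, at which 2 of the 3 values shown sit.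

Compound 4 (`C=C(CC)C(=O)c1ccc(OCC(=O)Nc2ccc(C(=O)O)cc2)c(Cl)c1Cl`) has hydrogen in place of hydroxy on an aromatic carbon, ortho to a carboxy group (hydrogen in place of hydroxy on an aromatic carbon).

Going by the values given here, the one measured step, an at least 1.6-fold lower number from compound 1 to compound 2 (0.22 log units; that floor lies within the scatter), changes the group on the amide-type nitrogen, so it gives no size for this change. Only a small step is expected, if any, towards lower numbers, with compound 2 at 14900 nM as the nearest anchor. The expected step is an at least 1.3-fold lower number from compound 3 to compound 4 (0.11 log units; that floor lies within the scatter). For compound 4 the estimate is 19000 nM, with an expected range of 9000 nM to 40000 nM.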

Compound 4, half-maximal effective concentration: 5000 nM
Estimate against measurement, compound 4: 3.8-fold (0.58 log units) above; measured number below the stated range.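

In this assay hydrogen in place of the hydroxy ortho to a carboxy group gives an at least 5.0-fold lower number from compound 3 to compound 4 (0.69 log units; beyond the scatter) and shows that the hydroxy at this position is not neutral. The 4-carboxyphenyl group also outdoes the other groups on the amide-type nitrogen, with a 3.0-fold lower number from compound 2 to compound 4 (0.47 log units; beyond the scatter) and an at least 5.0-fold lower number from compound 1 to compound 4 (0.69 log units; beyond the scatter) as the steps on this read-out. The steps from compound 1 and compound 3 are floors only, because each of those compounds sits at a limit: the limit of > 25000 nM in this assay, at which 2 of the 4 values shown sit.

From the compounds shown here alone, whether a methoxy, a fluorine or an amine at this position would match hydrogen stays open. So does the effect of a methyl ester in place of the carboxylic acid of compound 4.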